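The source may hold more compounds than are shown below. What is called first, only, known or untested is meant among the compounds shown, and "the series" means these compounds.

Measured compounds:
compound 1 `Cc1n[nH]c2ccc(-c3nc4cnc(N5CCN(C)CC5)cn4c3Nc3ccccc3F)cc12` — 0%
compound 2 `Cc1n[nH]c2ccc(-c3nc4cnc(N5CCN(C)CC5)cn4c3Nc3ccccc3Cl)cc12` — "not determined" (no result reported)
compound 3 `Cc1n[nH]c2ccc(-c3nc4cnc(N5CCC(C)CC5)cn4c3Nc3ccc(Cl)cc3)cc12` — 12.6%

All three share one core; they differ only in the ring on the amine nitrogen and in the saturated ring at the far end. In a functional assay on CWR22R cells (Homo sapiens) for inhibition, with a stated time of 120 h, tested at 10 uM (a lower number here means less inhibition, a higher number more inhibition at the concentration tested (going by the name of the read-out)), compound 1 gives 0%, and compound 3 gives 12.6%. These two values lie within the usual scatter of each other, so neither shows more inhibition than the other. For the measured compounds named here, compound 2 has no number in this assay; it cannot be placed on the scale, and no step from it to another compound can be measured.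

The unmeasured compound 4 `Cc1n[nH]c2ccc(-c3nc4cnc(N5CCN(C)CC5)cn4c3Nc3ccc(Br)cc3)cc12` arises from compound 2 by one change: 4-bromophenyl in place of 2-chlorophenyl on a nitrogen on an aromatic ring. Because compound 2 carries no value, the size of this step in this assay cannot be read from the data; the expectation for compound 4 rests on compound 1 with 0% and compound 3 with 12.6%, both low. Compound 4 is therefore expected to show weak inhibition, estimated at 6%, within a range from 0% to 20%.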

Compound 4, a percentage reported as inhibition, at one concentration (the size of the read-out at that concentration, not a potency): 11.7%
Beside the measured number, compound 4's estimate is 5.7 percentage points below it; low and high end bracket the measured number.
By their numbers in this assay, from the lowest: compound 1; then compounds 4 and 3 (each within the scatter of the next).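

Swapping the ring on the amine nitrogen can change the read-out in this assay: with the rest of the molecule held the same, 4-bromophenyl in place of 2-fluorophenyl gives a number 11.7 percentage points higher from compound 1 to compound 4 (beyond the scatter), the first step at this position that can be sized. The change is still small in absolute terms, since compound 4 reaches only 11.7% at the single concentration tested. The step from compound 2 cannot be read, and no supporting data explain the step from compound 1 to compound 4.

This swap changes both the halogen and its place on the ring, so the two effects cannot be separated. The compounds shown leave open how 4-fluorophenyl or 2-bromophenyl would compare, and whether a group without a halogen, such as 4-methoxyphenyl, would fit the same picture.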